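The source may hold more compounds than are shown below. What is called first, only, known or untested is meant among the compounds shown, and "the series" means these compounds.

Three compounds have been measured in an ADME assay on Vero cells (Chlorocebus sabaeus) for cytotoxicity, read by WST assay, tested at 50 ug/mL; a higher number here means a weaker effect of the compound at the concentration tested, a lower number a stronger effect:

Compound 1, `O=C(/C=C/c1ccccc1)O/C(=N/C1CCCCC1)NC1CCCCC1`, gives 83.9%.
Compound 2, `COC(=O)[C@H](COC(=O)/C=C/c1ccc(C)cc1)NC(=O)/C=C/c1ccc(C)cc1`, gives 28.8%.
Compound 3, `COC(=O)[C@@H]1COC(/C=C/c2ccc(F)cc2)=N1`, gives 91.6%.

Compound 3 stands with the highest of the three numbers in this assay. The nearest to it is compound 1, whose number lies within the usual scatter of the number of compound 3, so the two cannot be told apart. The furthest is compound 2, whose number falls well beyond the scatter below that of compound 3.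

The next compound, compound 4, `COC(=O)[C@@H]1COC(/C=C/c2ccc(OC)cc2)=N1`, has not yet been measured in this assay. It differs from compound 3 in one place: methoxy in place of fluoro on an aromatic carbon. Among the measured compounds shown here, no pair of measured compounds that differ by only this kind of change is available, so the size of such a step has not been seen in this set. For the measured compounds named here, nothing among the measured compounds points to a large step away from compound 3, and the change is expected to leave the number within, or only a little beyond, the scatter, in either direction. Compound 4 is therefore expected to give about 88%, with a range from 70% to 100%. This estimate means a step from compound 3 to compound 4 of a number 3.6 percentage points lower from compound 3 to compound 4 (within the scatter), which is expected to stay within the scatter.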

Compound 4, a percentage reported as activity, at one concentration (the size of the read-out at that concentration, not a potency): 94.8%
Compound 4: middle estimate off by 6.8 percentage points, on the low side, within the range that was stated.
By their numbers in this assay, from the lowest: compound 2; then compounds 1, 3 and 4 (each within the scatter of the next, the first and the last beyond it).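

In this assay, putting methoxy in place of fluoro on an aromatic carbon, para to a large group, gives a number 3.2 percentage points higher from compound 3 to compound 4 (within the scatter) and so provides the first step seen at this position. The exchange, in which one fluorine leaves and a carbon and an oxygen enter along with one hydrogen-bond acceptor, leaves the two compounds indistinguishable in this read-out, so this position accepts either group without a step beyond the scatter in this one pair. No measurement available here accounts for this outcome.

This single step leaves open whether the same position would hold its number with a group of a different kind, such as an amine or a carboxylic acid, or with a longer chain in place of the methoxy. Among the compounds shown here, it also leaves open whether the exchange of fluoro for methoxy would give a similarly small step on another core, since only this one pair shows it.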